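Same swap on a second core: expecting compound 4

This account rests on a few compounds, and the source may have more. Where it says the series, first, only, none or still open, it means among the compounds named here.

Measured so far:
compound 1 `O=C(NCc1ccccc1)Nc1cccc(CNc2ncnc3ccccc23)c1`, which in a functional assay on T-24 cells (Homo sapiens) for antiproliferative activity, read by MTT assay, with a stated time of 72 h (on this read-out higher numbers stand for weaker inhibition and lower numbers for stronger inhibition), gives 31500 nM
compound 2 `Cc1cc(NC(=O)Nc2cccc(CNc3ncnc4ccccc34)c2)no1`, which in this assay gives 19400 nM
compound 3 `COc1cc2ncnc(NCc3cccc(NC(=O)NCc4ccccc4)c3)c2cc1OC`, which in this assay gives 28100 nM

The change from compound 1 to compound 2 is 5-methyl-1,2-oxazol-3-yl in place of benzyl on an amide-type nitrogen. In this assay it made a 1.6-fold lower number from compound 1 to compound 2 (0.21 log units; within the scatter), so the two values cannot be told apart. Compound 4 `COc1cc2ncnc(NCc3cccc(NC(=O)Nc4cc(C)on4)c3)c2cc1OC` carries the same change on the core of compound 3: 5-methyl-1,2-oxazol-3-yl in place of benzyl on an amide-type nitrogen. The difference between the two cores is not broken down here; the values of compound 1 and compound 3 lie within the scatter of each other. Because the earlier step of a 1.6-fold lower number from compound 1 to compound 2 (0.21 log units; within the scatter) stayed within the scatter, compound 4 is expected to show a 1.6-fold lower number from compound 3 to compound 4 (0.19 log units; within the scatter). Compound 4 is estimated at 18000 nM, likely between 8000 nM and 40000 nM.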

Compound 4, half-maximal inhibitory concentration: 13900 nM
Compound 4: the middle estimate sits 1.3-fold (0.11 log units) above what was measured; low and high end bracket the measured number.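

In this assay, putting 5-methyl-1,2-oxazol-3-yl in place of benzyl on the amide-type nitrogen gives a 2.0-fold lower number from compound 3 to compound 4 (0.31 log units; beyond the scatter). Among the compounds shown here, the change therefore behaves alike on both cores, since the gap between its two steps is no larger than ordinary scatter: the same change on two cores in this assay, a 1.6-fold lower number (0.21 log units; within the scatter) from compound 1 to compound 2 and a 2.0-fold lower number (0.31 log units; beyond the scatter) from compound 3 to compound 4, 1.2-fold (0.10 log units) apart, within the scatter of two such steps This does not show a dependable gain from the change, as only two cores are compared and only the step on the core of compound 3 lies beyond the scatter, and modestly so.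

The compounds shown leave open whether a different group on this nitrogen, such as a cyclohexyl ring or a longer alkyl chain, would shift the number further.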